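Removing a methyl from a weak growth inhibitor

The source may report more compounds than this note shows. Statements on the series, on what has been measured and on what is new or still open speak of the compounds shown alone.

Compound 1 `CC1=C(C(=O)OCc2ccccc2)C(c2ccc(-c3ccccc3)cc2)NC(=S)N1Cc1ccc(-c2nnn[nH]2)cc1`: 87000 nM
Compound 2 `CC1=C(C(=O)OCc2ccccc2)C(c2ccc(-c3ccccc3C)cc2)NC(=S)N1CCCCCc1nnn[nH]1`: 100000 nM

In a toxicity assay on RMS13 cells (Homo sapiens) for inhibition, with a stated time of 24 h (on this read-out lower numbers stand for stronger inhibition of growth and higher numbers for weaker inhibition of growth), compound 2 gives 100000 nM, the highest of the two numbers, and compound 1 gives 87000 nM, a gap within the usual scatter. Compound 3 `CC1=C(C(=O)OCc2ccccc2)C(c2ccc(-c3ccccc3)cc2)NC(=S)N1CCCCCc1nnn[nH]1` has not been measured. It differs from compound 2 by hydrogen in place of methyl on an aromatic carbon. Going by the values given here, both measured compounds inhibit growth only weakly, and no measured pair separates this change, so the expected step from compound 2 to compound 3 is a 1.1-fold lower number from compound 2 to compound 3 (0.02 log units; within the scatter), none beyond the scatter. Compound 3 is estimated at 95000 nM, with a range from 45000 nM to 200000 nM.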

Compound 3, concentration for 50% growth inhibition: 110000 nM
The estimate for compound 3 lay 1.2-fold (0.06 log units) below the measured number; measured number inside the range.
By their numbers in this assay, from the lowest: compounds 1, 2 and 3 (each within the scatter of the next).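

In this assay, going from 2-methylphenyl to phenyl gives a 1.1-fold higher number from compound 2 to compound 3 (0.04 log units; within the scatter), so at this position the methyl makes no difference that can be read. Putting 4-(1H-tetrazol-5-yl)butyl in place of 4-(1H-tetrazol-5-yl)phenyl gives a 1.3-fold higher number from compound 1 to compound 3 (0.10 log units; within the scatter), so this swap also leaves growth inhibition within the scatter. Nothing measured here accounts for how close these numbers lie. Still open, as far as these compounds go, is whether an amine or a carboxylic acid in place of the methyl would move the number beyond the scatter. A longer chain carrying the tetrazole is equally untested among these compounds.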